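The source may hold more compounds than are shown below. What is called first, only, known or untested is meant among the compounds shown, and "the series" means these compounds.

Measured so far:
compound 1 `C[Se]c1nc(N)c2ccccc2n1` – > 100000 nM
compound 2 `[SeH]c1nc([SeH])c2ccccc2n1` – 9030 nM

Within the data shown here, in a functional assay on CCRF-CEM cells (Homo sapiens) for cytotoxicity, read by MTT assay, with a stated time of 72 h (a higher number here means that more compound is tolerated, a lower number that less compound is tolerated), compound 2 gives 9030 nM, the only true number among the values shown. Compound 1 reaches only a limit of the assay in this assay, (the limit of > 100000 nM in this assay, at which 1 of the 2 values shown sits). Compound 3 `Nc1nc([SeH])nc2ccccc12` has not been tested yet. It differs from compound 2 by one nitrogen atom in place of one selenium atom, on an aromatic carbon. Among the measured compounds shown here, no step between two measured compounds is known here. The expected step from compound 2 to compound 3 is a 3.3-fold higher number from compound 2 to compound 3 (0.52 log units; beyond the scatter), towards more compound being tolerated. Compound 3 is therefore estimated at 30000 nM, with a range from 8000 nM to 100000 nM.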

Compound 3, concentration lethal to 50% of the cells: 79100 nM
The estimate for compound 3 lay 2.6-fold (0.42 log units) below the measured number; the range from low to high includes it.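

In this assay, amino in place of selenium on this aromatic carbon, next to the ring nitrogen, gives an 8.8-fold higher number from compound 2 to compound 3 (0.94 log units; beyond the scatter), the first measured size for this change. On the selenium at the other position, hydrogen in place of methyl gives an at least 1.2-fold lower number from compound 1 to compound 3 (0.10 log units; that floor lies within the scatter), which is too small to show a real difference. Compound 1 stands at a limit of the assay, not at a true number: the limit of > 100000 nM in this assay, at which 1 of the 3 values shown sits.

Still open, on these data alone, is how a carboxylic acid or a longer chain at the amino position would compare with amino or selenium.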